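The source may hold more compounds than are shown below. What is called first, only, known or untested is meant among the compounds shown, and "the series" means these compounds.

Compound 1, with the structure `COc1cc(/C=N/Nc2nc(-c3ccc(F)c(F)c3)cs2)cc(Br)c1OC`, and compound 2, with the structure `COc1cc(/C=N/Nc2nc(-c3ccc(F)c(F)c3)cs2)c(Br)c(Br)c1OC`, share one core and were both tested in a functional assay on A549 cells (Homo sapiens) for inhibition, read by MTT assay, with a stated time of 48 h; on this read-out lower numbers stand for stronger inhibition and higher numbers for weaker inhibition. In this assay compound 1 gives 21100 nM, while compound 2 gives 8380 nM. The two differ in a single place, (hydrogen in place of bromo on an aromatic carbon), and that change produced a 2.5-fold higher number from compound 2 to compound 1 (0.40 log units; beyond the scatter).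

Compound 3, with the structure `Fc1ccc(/C=N/Nc2nc(-c3ccc(Br)cc3)cs2)cc1F`, is built on another core; how its core differs from that of compound 2 is not broken down here. In this assay compound 3 reaches only > 100000 nM, which is a limit of the assay and not a number. Such a limit is the limit of > 100000 nM in this assay, at which 1 of the 3 values shown sits.

Compound 4, with the structure `Fc1ccc(/C=N/Nc2nc(-c3ccccc3)cs2)cc1F`, has not yet been measured. It differs from compound 3 by hydrogen in place of bromo on an aromatic carbon. Within the data shown here, this is the same kind of change as the one from compound 2 to compound 1, though the surroundings differ: in compound 2 the bromo sits ortho to a bromo group, ortho to a large group, meta to a methoxy group and para to a methoxy group, whereas in compound 3 it sits para to a large group. The step from compound 3 to compound 4 is expected to be a step that the limit leaves unreadable from compound 3 to compound 4, a modest weakening resting on a 2.5-fold higher number from compound 2 to compound 1 (0.40 log units; beyond the scatter). Because compound 3 already stands at the limit of > 100000 nM in this assay, at which 1 of the 3 values shown sits, a number may again fail to appear. Compound 4 is therefore estimated to give 200000 nM, expected to lie between 60000 nM and 700000 nM.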

Compound 4, half-maximal inhibitory concentration: 91400 nM
Compound 4: the middle estimate sits 2.2-fold (0.34 log units) above what was measured; the range from low to high includes it.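

In this assay, swapping bromo for hydrogen on the aromatic carbon, which turns the 4-bromophenyl of compound 3 into the phenyl of compound 4, gave an at least 1.0-fold lower number from compound 3 to compound 4 (0.03 log units; that floor lies within the scatter), whereas the same swap on the other core gave a 2.5-fold higher number from compound 2 to compound 1 (0.40 log units; beyond the scatter). The size and direction of this change therefore did not carry over from one core to the other, which is a warning against reusing a step measured on a different core, even when the swap itself is identical: the same change on two cores in this assay, a 2.5-fold higher number (0.40 log units; beyond the scatter) from compound 2 to compound 1 and an at least 1.0-fold lower number (0.03 log units; that floor lies within the scatter) from compound 3 to compound 4, at least 2.7-fold (0.44 log units) apart, beyond the scatter of two such steps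

Compound 3 stands at > 100000 nM, which is a limit of the assay and not a number, so its step to compound 4 is known only as a floor, and its full size stays unknown, as does the reason the two cores part ways: the limit of > 100000 nM in this assay, at which 1 of the 4 values shown sits.

The compounds shown leave open whether the gap between the cores holds for other replacements, for example an amine or a carboxylic acid in the place of that bromo. Among these compounds, with only two pairs in hand, they also leave open how the swap behaves on any further core, and whether either of the two steps is the more typical one.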